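Urea series: aryl to cyclohexyl on the urea nitrogen

The source may report more compounds than this note shows. Statements on the series, on what has been measured and on what is new or still open speak of the compounds shown alone.

The series shares a core carrying a urea; compound 1 `CN(C)c1ccc(NC(=O)Nc2cccc(CNc3nccnc3Cl)c2)cc1` bears a 4-(dimethylamino)phenyl on the urea nitrogen. In a functional assay on T-24 cells (Homo sapiens) for antiproliferative activity, read by MTT assay, with a stated time of 48 h (on this read-out higher numbers stand for weaker inhibition and lower numbers for stronger inhibition), compound 1 gives 20200 nM, the highest number of the three measured. Compound 2 `Cc1cccc(NC(=O)Nc2cccc(CNc3nccnc3Cl)c2)c1` gives 9570 nM and compound 3 `O=C(Nc1cccc(CNc2nccnc2Cl)c1)Nc1ccc(Cl)cc1Cl` gives 5740 nM. Both replacements of the aryl group on that nitrogen lowered the number: a 2.1-fold lower number from compound 1 to compound 2 (0.32 log units; beyond the scatter) and a 3.5-fold lower number from compound 1 to compound 3 (0.55 log units; beyond the scatter); between the two substituted aryls the step was a 1.7-fold lower number from compound 2 to compound 3 (0.22 log units; within the scatter).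

Compound 4 `O=C(Nc1cccc(CNc2nccnc2Cl)c1)NC1CCCCC1` is not yet measured. It differs from compound 1 as follows: cyclohexyl in place of 4-(dimethylamino)phenyl on an amide-type nitrogen. The change bearing on it is the two exchanges at the same nitrogen, both of modest size and both toward lower numbers, though neither involved a non-aromatic ring, so the evidence is indirect. A modest step of the same direction is expected, a 2.2-fold lower number from compound 1 to compound 4 (0.35 log units; beyond the scatter), with wide uncertainty. Compound 4 is thus estimated at 9000 nM in this assay, with a range of 3500 nM to 25000 nM.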

Compound 4, half-maximal inhibitory concentration: > 40000 nM
Compound 4 was reported as a limit (the forecaster's own chance of this, stated with the estimate: 5%); middle value at least 4.4-fold (0.64 log units) from the limit.
By their numbers in this assay, from the lowest: compounds 3 and 2 (each within the scatter of the next); then compound 1. At a limit, above all of these: compound 4.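

In this assay compound 4 is reported only as a limit: the limit of > 40000 nM in this assay, at which 1 of the 4 values shown sits.

Within the data shown here, the earlier exchanges at this amide-type nitrogen swapped one aryl for another and only lowered the number, whereas cyclohexyl is the first group here to move it upward, with an at least 6.9-fold higher number from compound 3 to compound 4 (0.84 log units; beyond the scatter) and an at least 4.1-fold higher number from compound 2 to compound 4 (0.62 log units; beyond the scatter). Against the weakest aryl the same direction appears, an at least 1.9-fold higher number from compound 1 to compound 4 (0.29 log units; that floor lies within the scatter), so of the four groups shown, only the one with a non-aromatic ring reaches the limit, and all three aryls give measured numbers.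

The compounds shown do not separate the loss of the aromatic ring from the particular shape of cyclohexyl. A phenyl without substituents, a benzyl, a cyclopentyl or an open chain such as n-butyl on the same nitrogen would bear on that question.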